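A few compounds are considered here, and "the series" means these few. Any claim that something is new, unique, unknown or untested is made for them only; others in the source may bear on it.

Three compounds share one core and differ only in a single group attached to it. Compound 1 `CCCNC(=O)c1sc2nc(-c3cccs3)cc(-c3ccccc3)c2c1N` carries a propylcarbamoyl group; in an assay for inhibition of 15-hydroxyprostaglandin dehydrogenase [NAD(+)] (Homo sapiens), read by fluorescence, with a stated time of 15 min, in the presence of a further agent that is not named here (a lower number here means a stronger inhibitor, a higher number a weaker inhibitor), compound 1 gives only a limit, > 7500 nM. Compound 2 `CCC[S+]([O-])c1sc2nc(-c3cccs3)cc(-c3ccccc3)c2c1N` carries a propylsulfinyl group, and in this assay compound 2 gives 2.1 nM. Compound 3 `CCCCS(=O)(=O)c1sc2nc(-c3cccs3)cc(-c3ccccc3)c2c1N` carries a butylsulfonyl group; in this assay compound 3 gives 25 nM, the higher of the two numbers, with the step of a 12-fold higher number from compound 2 to compound 3 (1.08 log units; beyond the scatter) separating it from compound 2.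

Compound 4 `CCCCC(=O)c1sc2nc(-c3cccs3)cc(-c3ccccc3)c2c1N` has not been measured. It differs from compound 3 by butylcarbonyl in place of butylsulfonyl on an aromatic carbon. Among the compounds with values here, two measured steps bear on this change: the step of an at least 300-fold lower number from compound 1 to compound 3 (2.47 log units; beyond the scatter), which replaced a carbamoyl-type group by the sulfonyl, and the step of a 12-fold higher number from compound 2 to compound 3 (1.08 log units; beyond the scatter). Within the data shown here, both show that changing this one group moves the number strongly, and that the carbonyl-bearing compound 1 was weakest, but no measured pair shows a ketone. The expectation for compound 4 is therefore a moderate rise, a 4.0-fold higher number from compound 3 to compound 4 (0.60 log units; beyond the scatter), with wide uncertainty. Compound 4 is estimated at 100 nM, within 10 nM to 2000 nM.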

Compound 4, half-maximal inhibitory concentration: > 7500 nM
Compound 4 was reported as a limit; the forecaster's own chance of this, stated with the estimate: 15%; middle value at least 75-fold (1.87 log units) away from the limit.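

Butylcarbonyl in place of butylsulfonyl on this aromatic carbon gives an at least 300-fold higher number from compound 3 to compound 4 (2.47 log units; beyond the scatter), and measured against the propylsulfinyl group the change gives an at least 3500-fold higher number from compound 2 to compound 4 (3.55 log units; beyond the scatter). The weak result of compound 1 therefore does not depend on the nitrogen of its propylcarbamoyl group: among the compounds shown, both carbonyl-linked groups fall out of the measurable range, while both sulfur-linked groups give real numbers. The step between compound 1 and compound 4 cannot be read, as both are limits rather than numbers: the limit of > 7500 nM in this assay, at which 2 of the 4 values shown sit.

Going by these compounds, whether a thioether, a sulfonamide or an ester on this carbon would keep the inhibition stays open. Compound 2 and compound 3 also differ in chain as well as in the sulfur group, so a propylsulfonyl or butylsulfinyl group would be needed to separate those two changes.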